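Swapping Methyl for Fluoro in a Cytotoxicity Series

The source may report more compounds than this note shows. Statements on the series, on what has been measured and on what is new or still open speak of the compounds shown alone.

Measured compounds:
Compound 1, `Cc1ccc(Cn2ccnc2/C=N/Nc2nc(NCCN(C)C)c3ccccc3n2)cc1`: 2980 nM
Compound 2, `CN(C)CCNc1nc(N/N=C/c2nccn2Cc2ccc(F)cc2)nc2ccccc12`: 3060 nM
Compound 3, `Cc1ccc(Cn2ccnc2/C=N/Nc2nc(NCCCN(C)C)c3ccccc3n2)cc1`: 3680 nM

The three measured compounds were tested in a functional assay on HepG2 cells (Homo sapiens) for cytotoxicity, read by MTT assay, with a stated time of 72 h (on this read-out lower numbers stand for stronger inhibition and higher numbers for weaker inhibition), and all three give numbers within the scatter of one another. Compound 2 differs from compound 1 by fluoro in place of methyl on an aromatic carbon, and that change gave a 1.0-fold higher number from compound 1 to compound 2 (0.01 log units; within the scatter). Compound 3 differs from compound 1 in the chain, by (dimethylamino)methyl in place of dimethylamino on a saturated chain carbon, two bonds along the chain from a nitrogen on an aromatic ring, which gave a 1.2-fold higher number from compound 1 to compound 3 (0.09 log units; within the scatter).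

Compound 4 `CN(C)CCCNc1nc(N/N=C/c2nccn2Cc2ccc(F)cc2)nc2ccccc12` is not yet measured. Going by the values given here, it differs from compound 3 by fluoro in place of methyl on an aromatic carbon, which is the same change, at the same place, as the one that leads from compound 1 to compound 2. The cores of compound 3 and compound 4 differ from those of compound 1 and compound 2 only in the chain, as described by the difference between compound 1 and compound 3.

Since the change from compound 1 to compound 2 gave a step within the scatter, compound 4 is expected to stay close to compound 3, with an estimated step of a 1.0-fold higher number from compound 3 to compound 4 (0.00 log units; within the scatter). Among the compounds with values here, this expectation rests on a single measured pair, compound 1 and compound 2, because a 1.0-fold higher number from compound 1 to compound 2 (0.01 log units; within the scatter) is the only example of the change available. Compound 4 is therefore estimated at 3700 nM in this assay, with a range from 1800 nM to 7500 nM reflecting the usual spread of repeated measurements.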

Compound 4, half-maximal inhibitory concentration: 2860 nM
Estimate against measurement, compound 4: 1.3-fold (0.11 log units) above; low and high end bracket the measured number.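

In this assay, fluoro in place of methyl on the core of compound 3 gave a 1.3-fold lower number from compound 3 to compound 4 (0.11 log units; within the scatter), and this reads the same as the earlier step on the core of compound 1: the same change on two cores in this assay, a 1.0-fold higher number (0.01 log units; within the scatter) from compound 1 to compound 2 and a 1.3-fold lower number (0.11 log units; within the scatter) from compound 3 to compound 4, 1.3-fold (0.12 log units) apart, within the scatter of two such steps The chain change, read on the fluoro compounds, gave a 1.1-fold lower number from compound 2 to compound 4 (0.03 log units; within the scatter), and it too agrees with its earlier reading on the methyl compounds: the same change on two cores in this assay, a 1.2-fold higher number (0.09 log units; within the scatter) from compound 1 to compound 3 and a 1.1-fold lower number (0.03 log units; within the scatter) from compound 2 to compound 4, 1.3-fold (0.12 log units) apart, within the scatter of two such steps So on these two cores, each change stays within the scatter wherever it is placed, but that agreement is one between steps too small to read, and it does not show that either change has a real effect of its own or that an effect of some size would carry from one core to the other.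

The compounds shown leave open whether another group at the same place on the benzyl ring, such as chloro, methoxy or trifluoromethyl, would move the number beyond the scatter. They also leave open what a longer chain, or a cyclic amine such as piperidine or morpholine in place of dimethylamino, would do on either core.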